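Swapping an aryl for a cycloalkyl at the acetoxy-bearing carbon

This account rests on a few compounds, and the source may have more. Where it says the series, first, only, none or still open, it means among the compounds named here.

Compound 3 `C=C(C(=O)c1ccc(OC)cc1)C(OC(C)=O)c1ccccc1F` gives 67300 nM in a functional assay on A549 cells (Homo sapiens) for inhibition, read by XTT assay, with a stated time of 48 h (a higher number here means a weaker inhibitor, a lower number a stronger inhibitor), the highest of the two numbers recorded there. Its nearest neighbour, compound 1 `COc1ccc(C(=O)/C(=C/c2ccccc2Cl)COC(=O)c2ccccc2)cc1`, gives 20100 nM in this assay. Compound 2 `COc1ccc(C(=O)/C(=C/c2ccccc2Cl)CCOC(C)=O)cc1` reaches only the limit of this assay, > 100000 nM, and that limit is the one at which one of the three recorded values sits (the limit of > 100000 nM in this assay, at which 1 of the 3 values shown sits). Within the data shown here, the single measured step, an at least 4.9-fold higher number from compound 1 to compound 2 (0.69 log units; beyond the scatter), concerns the ester on the chain and not the group at the acetoxy-bearing carbon.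

Compound 4 `C=C(C(=O)c1ccc(OC)cc1)C(OC(C)=O)C1CCCCC1` differs from compound 3 by cyclohexyl in place of 2-fluorophenyl on a saturated chain carbon bound to a double-bonded chain carbon and an oxygen next to a carbonyl group. Among the measured compounds shown here, no measured step touches this position, so the direction of the change cannot be read from the recorded compounds. With nothing to point either way, the expected step in this assay, a 1.0-fold higher number from compound 3 to compound 4 (0.02 log units; within the scatter), is estimated as none beyond the scatter, and compound 4 is expected to give about 70000 nM, in a range from 25000 nM to 200000 nM.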

Compound 4, half-maximal inhibitory concentration: > 100000 nM
Compound 4 ended at the assay's limit; the forecaster's own chance of this, stated with the estimate: 35%; middle value at least 1.4-fold (0.15 log units) from the limit.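

Among these compounds, the first measured step at this position is an at least 1.4-fold higher number from compound 3 to compound 4 (0.17 log units; that floor lies within the scatter) and gives a floor, not a size, so the true change may be small or large. It does show that in this assay the number did not fall with cyclohexyl in place of 2-fluorophenyl on this carbon, so this swap brought no gain. The value of compound 4 is a limit of the assay, and compound 4 is the second compound shown to sit there: the limit of > 100000 nM in this assay, at which 2 of the 4 values shown sit.

The compounds shown leave open how far past that limit compound 4 lies. They also leave open whether a plain phenyl, a cyclopentyl or a cyclohexyl carrying an amine at this carbon would give a number nearer that of compound 3.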